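A longer alcohol chain in place of a short nitrile

A few compounds are considered here, and "the series" means these few. Any claim that something is new, unique, unknown or untested is made for them only; others in the source may bear on it.

Three measured compounds share one core and differ in two side chains. Compound 1 `CCCc1cc(C(C)=O)c(O)cc1OCCCCC#N` gives 37% in an assay on isolated protein for binding affinity to leukotriene B4 receptor 1 (Homo sapiens), tested at 1 uM; on this read-out higher numbers stand for more inhibition at the one concentration tested (going by the name of the read-out) and lower numbers for less inhibition. Within the data shown here, compound 2 `CCCCc1cc(C(C)=O)c(O)cc1OCCCCC#N` gives 13% in this assay; the step of a number 24 percentage points lower from compound 1 to compound 2 (beyond the scatter) is the only single-change step measured here. Compound 3 `C=CCc1cc(C(C)=O)c(O)cc1OCC#N` gives 2% in this assay, the lowest of the three numbers and beyond the scatter from both compound 2 and compound 1. Compound 4 `C=CCc1cc(C(C)=O)c(O)cc1OCCCCO` has not yet been measured. It differs from compound 3 by 3-hydroxypropyl in place of cyano on a saturated chain carbon bound to an oxygen on an aromatic ring. Among the measured compounds shown here, no measured step touches this part of the molecule: the one step known concerns the chain on the other side of the ring, and compound 1 and compound 3 differ in two places at once, so their gap cannot be assigned to either change. The expectation for compound 4 therefore rests on little, and an upward step of a number 13 percentage points higher from compound 3 to compound 4 (beyond the scatter) is estimated with wide uncertainty. Compound 4 is expected to give 15%, between 0% and 45%.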

Compound 4, a percentage reported as inhibition, at one concentration (the size of the read-out at that concentration, not a potency): 9%
Beside the measured number, compound 4's estimate is 6 percentage points above it, and the stated range covers the measured number.
By their numbers in this assay, from the lowest: compounds 3, 4 and 2 (each within the scatter of the next, the first and the last beyond it); then compound 1.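

Among these compounds, this is the only measured step at this position, and replacing cyano with 3-hydroxypropyl, which turns cyanomethoxy into 4-hydroxybutoxy, gives a number 7 percentage points higher from compound 3 to compound 4 (within the scatter) in this assay. The short nitrile chain and the longer alcohol chain therefore cannot be told apart in this assay, even though the entering group brings a hydrogen-bond donor that cyano lacks. Nothing available explains this result.

The swap changes the chain length and the end group together, so the compounds shown cannot separate the two; a nitrile on the longer chain, with the rest of compound 4 kept, would address that. On these data alone, it also remains open whether a carboxylic acid or an amine at the end of this chain would give a number clearly different from those of compound 3 and compound 4.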